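The compounds below may be only part of what the source reports. "The series", "measured", "known", "first", "only" and "open" are said of these compounds alone.

Working notes on the series. In an assay on isolated protein for inhibition of Amine oxidase [flavin-containing] B (Homo sapiens), read by spectrophotometry (on this read-out lower numbers stand for stronger inhibition and higher numbers for weaker inhibition), compound 2 `Clc1ccccc1/C=N/Nc1nc2ccccc2nc1Cc1ccccc1` gives 87000 nM, the lowest of the three numbers: compound 1 `C(=N/Nc1nc2ccccc2nc1Cc1ccccc1)\c1ccccc1` gives 320000 nM, compound 3 `C/C(=N\Nc1nc2ccccc2nc1Cc1ccccc1)c1ccccn1` gives 980000 nM. Compound 4 `O=[N+]([O-])c1ccc(/C=N/Nc2nc3ccccc3nc2Cc2ccccc2)cc1` is not yet measured; relative to compound 2 the change is 4-nitrophenyl in place of 2-chlorophenyl on a carbon with a double bond to nitrogen.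

Of the measured steps, a 3.7-fold lower number from compound 1 to compound 2 (0.57 log units; beyond the scatter) is the one that bears on this change, as it shows the effect of the chloro that now leaves; an 11-fold higher number from compound 2 to compound 3 (1.05 log units; beyond the scatter) concerns a different ring and is less informative. Loss of the chloro is expected to cost most of that gain, while the effect of the nitro on this ring has no precedent here. The step from compound 2 to compound 4 is therefore expected to be a 2.9-fold higher number from compound 2 to compound 4 (0.46 log units; beyond the scatter), a modest rise. Compound 4 is estimated at 250000 nM, between 60000 nM and 900000 nM.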

Compound 4, half-maximal inhibitory concentration: 960000 nM
Estimate against measurement, compound 4: 3.8-fold (0.58 log units) below, and the stated range ends below it.
By their numbers in this assay, from the lowest: compound 2; then compound 1; then compounds 4 and 3 (each within the scatter of the next).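

Going from 2-chlorophenyl to 4-nitrophenyl on this carbon gives an 11-fold higher number from compound 2 to compound 4 (1.04 log units; beyond the scatter) and erases the gain seen with the chloro. Measured against the unsubstituted phenyl, nitro in place of hydrogen gives a 3.0-fold higher number from compound 1 to compound 4 (0.48 log units; beyond the scatter) and so moves the number the opposite way from the chloro. Nothing available explains this opposite movement.

From the compounds shown here alone, whether it follows the group or its place on the ring stays open, since 2-chlorophenyl and 4-nitrophenyl differ in both. Going by these compounds, the effect of an amine or a methoxy group on this ring also remains open.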